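Thiocyanate to methylsulfinyl on the nucleoside: cytotoxicity note

The compounds below may be only part of what the source reports. "The series", "measured", "known", "first", "only" and "open" are said of these compounds alone.

Measured so far:
compound 1 `OC[C@H]1C[C@@H](Cn2cnc3c(-c4ccc(Cl)cc4)ncnc32)c2ccccc21` gives 8440 nM
compound 2 `N#CSc1cn([C@H]2C[C@H](O)[C@@H](CO)O2)c(=O)[nH]c1=O` gives 78900 nM
compound 3 `OC[C@H]1C[C@@H](Cn2cnc3c(NC4CC4)ncnc32)c2ccccc21` gives > 200000 nM

In an ADME assay on L1210/0 cells (Mus musculus) for cytotoxicity, with a stated time of 48 h (on this read-out higher numbers stand for weaker inhibition and lower numbers for stronger inhibition), compound 2 gives the highest of the two numbers shown, compound 1 the lower. Compound 3 sits at a limit of the assay, not a number. For the measured compounds named here, the only measured step, an at least 23-fold higher number from compound 1 to compound 3 (1.37 log units; beyond the scatter), concerns a different exchange on a different core and does not bear directly on the change followed here. Compound 4 `C[S+]([O-])c1cn([C@H]2C[C@H](O)[C@@H](CO)O2)c(=O)[nH]c1=O` differs from compound 2 by a group of 3 heavy atoms (1 carbon, 1 oxygen, 1 sulfur; no ring) in place of a group of 3 heavy atoms (1 carbon, 1 nitrogen, 1 sulfur; no ring), on an aromatic carbon. Going by the values given here, with no measured step that speaks to this exchange, no shift beyond the scatter is expected; the upper end of the range approaches (the limit of > 200000 nM in this assay, at which 1 of the 3 values shown sits). Compound 4 is therefore estimated at 90000 nM, between 30000 nM and 200000 nM. The expected step is a 1.1-fold higher number from compound 2 to compound 4 (0.06 log units; within the scatter).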

Compound 4, half-maximal inhibitory concentration: > 200000 nM
Compound 4: a limit, no number; the forecaster's own chance of this, stated with the estimate: 25%; at least 2.2-fold (0.34 log units) between middle value and limit.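

In this assay, cyanosulfanyl giving way to methylsulfinyl on this aromatic carbon produces an at least 2.5-fold higher number from compound 2 to compound 4 (0.40 log units; beyond the scatter), so the read-out of the nucleoside responds to the group at this position. Compound 4 is a limit of the assay and not a number, and the step has only a lower bound: the limit of > 200000 nM in this assay, at which 2 of the 4 values shown sit. Of the two groups shown here, only cyanosulfanyl leaves a number inside the measured range.

From the compounds shown here alone, whether the nitrile or the sulfur matters more stays open; a methylsulfanyl group, a bromine or an amine on this carbon would help separate them. Also open, going by these compounds, is whether the same exchange carries over to another core.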